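Cyclopropylmethyl for Ethyl on Two Pyrrolidine-free Aminoazine Cores

The compounds below may be only part of what the source reports. "The series", "measured", "known", "first", "only" and "open" are said of these compounds alone.

Of the compounds shown here, three have been measured in a functional assay on A549 cells (Homo sapiens) for antiproliferative activity, read by MTT assay, with a stated time of 48 h (on this read-out higher numbers stand for weaker inhibition and lower numbers for stronger inhibition), and a fourth awaits its number. Compound 1, `CCNc1ccc2ncc(-c3cnn(C)c3)cc2n1`, carries an ethylamino group on its core. Compound 2, `Cn1cc(-c2cnc3ccc(NCC4CC4)nc3c2)cn1`, differs from it by cyclopropyl in place of methyl on a saturated chain carbon bound to a nitrogen on an aromatic ring. Compound 3, `CCNc1nccc2ncc(-c3cnn(C)c3)cc12`, is built from the same atoms as compound 1 but joined differently; the difference between the two cores is not broken down here. Compound 4, `Cn1cc(-c2cnc3ccnc(NCC4CC4)c3c2)cn1`, differs from compound 3 by cyclopropyl in place of methyl on a saturated chain carbon bound to a nitrogen on an aromatic ring, the same change as that from compound 1 to compound 2.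

In this assay compound 1 returns only a limit, > 50000 nM. Compound 2 likewise returns only a limit, > 50000 nM. The result is a step that the two limits leave unreadable from compound 1 to compound 2. Within the data shown here, compound 3 gives 40700 nM, the one actual number in the set.

The step from compound 3 to compound 4 is expected to be a 1.1-fold higher number from compound 3 to compound 4 (0.04 log units; within the scatter), a change too small to carry compound 4 far from the number of compound 3, since the same change in the measured pair left a step that the two limits leave unreadable from compound 1 to compound 2, and since the limit of > 50000 nM in this assay, at which 2 of the 3 values shown sit, shows how close to the edge of measurement this series sits. Compound 4 is therefore expected to give about 45000 nM in this assay, with a likely range from 15000 nM to 150000 nM, and a real chance that only a limit is reported.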

Compound 4, half-maximal inhibitory concentration: 8900 nM
The estimate for compound 4 lay 5.1-fold (0.70 log units) above the measured number; measured number outside the range, below it.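

In this assay the replacement of methyl by cyclopropyl on a saturated chain carbon bound to a nitrogen on an aromatic ring gives a 4.6-fold lower number from compound 3 to compound 4 (0.66 log units; beyond the scatter) on the core of compound 3, so on that core the change from ethylamino to (cyclopropylmethyl)amino has a readable result. The same change on the core of compound 1 cannot be read, since compound 1 and compound 2 each return only a limit, which leaves it undecided whether the result carries over to that core: the limit of > 50000 nM in this assay, at which 2 of the 4 values shown sit. The series therefore offers a single readable pair, which shows what the change did on one core but gives no rule for carrying it from one core to another.

As far as these compounds go, it remains open whether a longer chain such as propyl, or a larger ring such as cyclobutyl in place of the cyclopropyl, would extend the result seen on the core of compound 3. From the compounds shown here alone, it is also open whether any such group would bring the core of compound 1 to a number that can be read in this assay and so allow the two cores to be compared.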